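The compounds below may be only part of what the source reports. "The series", "measured", "known", "first", "only" and "open" are said of these compounds alone.

Within the data shown here, in a functional assay on HepG2 cells (Homo sapiens) for inhibition, read by MTT assay, with a stated time of 72 h (a lower number here means a stronger inhibitor, a higher number a weaker inhibitor), compound 2 `N#Cc1cccc(-n2cc(COc3cccc(NC(=O)Nc4ccc(Cl)c(C(F)(F)F)c4)c3)nn2)c1` gives 2760 nM, one of only two numbers so far; the other comes from compound 1 `Cc1ccccc1-n1cc(COc2cccc(NC(=O)Nc3ccc(Cl)c(C(F)(F)F)c3)c2)nn1`, which gives 3440 nM, and the step of a 1.2-fold lower number from compound 1 to compound 2 (0.10 log units; within the scatter) stays within the scatter. Compound 3 `N#Cc1ccc(-n2cc(COc3cccc(NC(=O)Nc4ccc(Cl)c(C(F)(F)F)c4)c3)nn2)cc1` differs from compound 2 by 4-cyanophenyl in place of 3-cyanophenyl on an aromatic nitrogen. Among the measured compounds shown here, the single measured step, a 1.2-fold lower number from compound 1 to compound 2 (0.10 log units; within the scatter), exchanged the whole group on that same aromtic nitrogen without leaving the scatter, so a shift of the nitrile alone is expected to move this assay by no more than the scatter, in no particular direction. Compound 3 is therefore estimated at 2800 nM, with a range from 1300 nM to 6000 nM. The expected step is a 1.0-fold higher number from compound 2 to compound 3 (0.01 log units; within the scatter).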

Compound 3, half-maximal inhibitory concentration: 2980 nM
The estimate for compound 3 lay 1.1-fold (0.03 log units) below the measured number; the range from low to high includes it.
By their numbers in this assay, from the lowest: compounds 2, 3 and 1 (each within the scatter of the next).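

In this assay, 4-cyanophenyl in place of 3-cyanophenyl on the aromatic nitrogen gives a 1.1-fold higher number from compound 2 to compound 3 (0.03 log units; within the scatter) and so does not separate the two compounds. Replacing 2-methylphenyl with 4-cyanophenyl gives a 1.2-fold lower number from compound 1 to compound 3 (0.06 log units; within the scatter) and also stays within the scatter, so all three groups at this position lie within the scatter of one another. Nothing available bears on why the numbers stay so close. The compounds shown leave open whether an amine or a carboxylic acid in place of the nitrile, or a longer chain in place of the whole aryl group, would move the number beyond the scatter.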